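Furan in place of thiophene on the fused core

The compounds below may be only part of what the source reports. "The series", "measured", "known", "first", "only" and "open" are said of these compounds alone.

Measured so far:
compound 1 `COc1cc(-c2nnc3n2NC(c2ccco2)C(C(=O)c2ccccc2F)S3)cc(OC)c1OC`: > 100000 nM
compound 2 `COc1ccc(C(=O)C2Sc3nnc(-c4cc(OC)c(OC)c(OC)c4)n3NC2c2cccs2)cc1`: 95900 nM

Among the measured compounds shown here, in a functional assay on PC-3 cells (Homo sapiens) for cytotoxicity, read by MTT assay, with a stated time of 48 h (on this read-out lower numbers stand for stronger inhibition and higher numbers for weaker inhibition), compound 2 gives 95900 nM, the only plain number in the set. For compound 1 the read-out is a limit, not a number: the limit of > 100000 nM in this assay, at which 1 of the 2 values shown sits. Compound 3 `COc1ccc(C(=O)C2Sc3nnc(-c4cc(OC)c(OC)c(OC)c4)n3NC2c2ccco2)cc1` is not yet measured; it differs from compound 2 by furan-2-yl in place of thiophen-2-yl on a saturated ring carbon, in words furan-2-yl in place of thiophen-2-yl on a saturated ring carbon. For the measured compounds named here, no step between measured compounds exists to size this change, so the expected step from compound 2 to compound 3 is none beyond the scatter, a 1.0-fold higher number from compound 2 to compound 3 (0.02 log units; within the scatter). Compound 3 is therefore estimated at 100000 nM, with a range from 40000 nM to 250000 nM, and a fair chance that only a limit is reported.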

Compound 3, half-maximal inhibitory concentration: > 100000 nM
Compound 3: only a limit was reported (the forecaster's own chance of this, stated with the estimate: 50%); the middle value sits exactly at the limit.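

In this assay, from the compounds shown here alone, furan-2-yl in place of thiophen-2-yl on a saturated ring carbon gives an at least 1.0-fold higher number from compound 2 to compound 3 (0.01 log units; that floor lies within the scatter), so this first reading of the position shows no change beyond the scatter, while the true size stays open on the upper side. The step between compound 1 and compound 3 cannot be read: both values are limits. Compound 3 joins compound 1 as a limit, which leaves most of the set without a plain number: the limit of > 100000 nM in this assay, at which 2 of the 3 values shown sit.

Going by these compounds, whether an aminomethyl group or a carboxylic acid on this ring carbon would bring the number clearly under the limit stays open.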